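Replacing the Benzimidazole of Compound 2 with a Tetrahydroisoquinoline

The compounds below may be only part of what the source reports. "The series", "measured", "known", "first", "only" and "open" are said of these compounds alone.

Compound 2 `c1cnc2c(c1)CCC[C@@H]2N(CCCN1CCNCC1)Cc1nc2ccccc2[nH]1` is the middle of the three measured compounds in an ADME assay on microsomes from liver (Rattus norvegicus) for metabolic stability, read by LC-MS, with a stated time of 10 min, tested at 0.5 uM (on this read-out higher numbers stand for a more stable compound and lower numbers for a less stable compound), where compound 2 gives 29%. Compound 1 `c1cnc(CN(CCCN2CCNCC2)[C@H]2CCCc3cccnc32)nc1` stands highest and in this assay compound 1 gives 68%; compound 3 `CCN1CCN(CCCN(C[C@H]2Cc3ccccc3CN2)[C@H]2CCCc3cccnc32)CC1` stands lowest and in this assay compound 3 gives 1%. Among the measured compounds shown here, the one measured step on the group bound to the amine nitrogen is a number 39 percentage points lower from compound 1 to compound 2 (beyond the scatter), a large drop on moving from compound 1 to compound 2.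

Compound 4 `c1ccc2c(c1)CN[C@@H](CN(CCCN1CCNCC1)[C@H]1CCCc3cccnc31)C2` differs from compound 2 as follows: 1,2,3,4-tetrahydroisoquinolin-3-yl in place of 1H-benzimidazol-2-yl on a saturated chain carbon bound to an amine nitrogen. For the measured compounds named here, no measured step covers this exact exchange, so the expectation rests on compound 3, which carries the same 1,2,3,4-tetrahydroisoquinolin-3-yl group and gives 1% in this assay, though compound 3 also bears an ethyl on the piperazine. A further drop is therefore expected, of about a number 21 percentage points lower from compound 2 to compound 4 (beyond the scatter), taking compound 4 to an estimated 8% in this assay, within a range of 0% to 25%.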

Compound 4, percent of the compound remaining: 100%
Compound 4: the middle estimate sits 92 percentage points below what was measured; the measured number lies above the stated range.
By their numbers in this assay, from the lowest: compound 3; then compound 2; then compound 1; then compound 4.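

In this assay, the position on a saturated chain carbon bound to an amine nitrogen proves far more tolerant than compound 3 suggested: 1,2,3,4-tetrahydroisoquinolin-3-yl in place of 1H-benzimidazol-2-yl gives a number 71 percentage points higher from compound 2 to compound 4 (beyond the scatter), and in place of pyrimidin-2-yl it gives a number 32 percentage points higher from compound 1 to compound 4 (beyond the scatter). The low number of compound 3 therefore does not follow from this group alone, since hydrogen in place of ethyl on an amine nitrogen in a ring gives a number 99 percentage points higher from compound 3 to compound 4 (beyond the scatter). No measurement shown here accounts for these differences.

As far as these compounds go, it remains open whether an ethyl on that ring nitrogen would have a similar effect alongside pyrimidin-2-yl or 1H-benzimidazol-2-yl, and whether a methyl or an acetyl there would behave like the ethyl. From the compounds shown here alone, the opposite configuration at the defined stereocentre of the 1,2,3,4-tetrahydroisoquinolin-3-yl group also remains open.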